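Hydrogen for Cyclopropyl on the Amide, Repeated Once

A few compounds are considered here, and "the series" means these few. Any claim that something is new, unique, unknown or untested is made for them only; others in the source may bear on it.

Measured compounds:
compound 1 `O=C(/C=C1\CCc2ccccc21)NC1CC1`: in a functional assay on the whole organism with Mus musculus as the target, in the rotarod test (a lower number here means that less compound is needed, a higher number that more compound is needed for the effect), compound 1 gives 235 mg/kg
compound 2 `NC(=O)/C=C1\CCc2ccccc21`: in this assay compound 2 gives 164 mg/kg
compound 3 `O=C(/C=C1\CCc2cc(F)ccc21)NC1CC1`: in this assay compound 3 gives 193 mg/kg

Compound 4 `NC(=O)/C=C1\CCc2cc(F)ccc21` has not yet been measured. The change from compound 3 to compound 4 is hydrogen in place of cyclopropyl on an amide-type nitrogen. The same change has already been made once, from compound 1 to compound 2, as hydrogen in place of cyclopropyl on an amide-type nitrogen, and there it gave a 1.4-fold lower number from compound 1 to compound 2 (0.16 log units; within the scatter). The two cores differ by fluoro in place of hydrogen on an aromatic carbon, which gave a 1.2-fold lower number from compound 1 to compound 3 (0.09 log units; within the scatter). The place of the amide change is the same in both pairs, so the two are the same kind of change on different cores.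

Resting on the step from compound 1 to compound 2 of a 1.4-fold lower number from compound 1 to compound 2 (0.16 log units; within the scatter), the step from compound 3 to compound 4 is expected to be a 1.4-fold lower number from compound 3 to compound 4 (0.14 log units; within the scatter). Compound 4 is therefore estimated at 140 mg/kg, with a likely range from 80 mg/kg to 250 mg/kg.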

Compound 4, dose for half-maximal effect: > 100 mg/kg
Compound 4 was reported as a limit; the forecaster's own chance of this, stated with the estimate: 5%; the middle value does not contradict the limit.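

In this assay compound 4 gives > 100 mg/kg, which is a limit and not a number. The steps to compound 4 from compound 3 and from compound 2 therefore cannot be read. The compounds shown leave open how hydrogen in place of cyclopropyl acts on the fluoro-bearing core.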